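The source may report more compounds than this note shows. Statements on the series, on what has been measured and on what is new or still open speak of the compounds shown alone.

Three measured compounds share one core and differ in the group on the ring amine nitrogen and in the aromatic ring at the far end. Compound 1, `CC(C)(C)OC(=O)N1CCC(O[C@H]2CC[C@H](Oc3ccc(S(C)(=O)=O)cc3F)CC2)CC1`, reaches 113% in a functional assay on isolated protein for agonist activity at Glucose-dependent insulinotropic receptor (Homo sapiens), read by HTRF and cAMP accumulation; a lower number here means a smaller maximal response, a higher number a larger maximal response. Compound 2, `CC(C)(C)OC(=O)N1CCC(O[C@H]2CC[C@H](Oc3ccc(C#N)cc3)CC2)CC1`, reaches 116% in this assay. Compound 3, `C[C@H](CF)OC(=O)N1CCC(O[C@H]2CC[C@H](Oc3cnc(S(C)(=O)=O)cn3)CC2)CC1`, reaches 108% in this assay. On the numbers alone compound 3 stands lowest of the three, but its gap to compound 1 and its gap to compound 2 both lie within the usual scatter of this kind of measurement, so the three values cannot be told apart and all three show a full or slightly more than full maximal response.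

Compound 4, `CC(C)c1noc(CN2CCC(O[C@H]3CC[C@H](Oc4cnc(S(C)(=O)=O)cn4)CC3)CC2)n1`, has not yet been measured. It differs from compound 3 in one place: a group of 9 heavy atoms (6 carbon, 2 nitrogen, 1 oxygen; one five-membered aromatic ring with 3 hetero atoms) in place of a group of 7 heavy atoms (4 carbon, 2 oxygen, 1 fluorine; no ring), on an amine nitrogen in a ring

Going by the values given here, no pair of measured compounds differing in one place is available, so there is no measured step to rest on. What is known is that all three measured values sit close together near full response. On that basis the step from compound 3 to compound 4 is expected to be no change at the digits printed from compound 3 to compound 4 (within the scatter), that is, nothing beyond the scatter. Compound 4 is accordingly estimated to reach about 108% in this assay, within a range from 95% to 121%.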

Compound 4, largest response reached (Emax), in percent of the reference or control that the assay uses: 102%
Estimate against measurement, compound 4: 6 percentage points above, within the range that was stated.
By their numbers in this assay, from the lowest: compounds 4, 3, 1 and 2 (each within the scatter of the next, the first and the last beyond it).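

In this assay, the exchange on the amine nitrogen in the ring gives a number 6 percentage points lower from compound 3 to compound 4 (within the scatter), so this single-place comparison does not separate the (3-isopropyl-1,2,4-oxadiazol-5-yl)methyl group from the group it replaces. It shows that this position can carry a five-membered aromatic ring with 3 hetero atoms, and that compound 4 still reaches 102% without the fluorine, the defined stereocentre or the double bond outside aromatic rings of the group in compound 3. Nothing available explains why the maximal response holds across this change.

What the compounds shown leave open is whether the same nitrogen would tolerate a quite different group, such as a plain alkyl chain, an amide or a carboxylic acid, and whether the oxadiazole exchange would give a similar result with the aromatic ring of compound 1 or compound 2 at the far end. Because only the largest response is given, they also leave open how the exchange affects the concentration needed to reach that response.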